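This account rests on a few compounds, and the source may have more. Where it says the series, first, only, none or still open, it means among the compounds named here.

Compound 2 `CN1CCC(NC(=O)c2ccc(Cn3nc(-c4cnn(C)c4)c4ccccc4c3=O)cc2)CC1` is the point of departure. In a functional assay on HeLa cells (Homo sapiens) for antiproliferative activity, read by MTT assay, with a stated time of 72 h (on this read-out lower numbers stand for stronger inhibition and higher numbers for weaker inhibition), compound 2 gives 28500 nM, the lowest of the two numbers shown. Compound 1 `Cn1cc(-c2nn(Cc3ccc(C(=O)N4CCCCC4)cc3)c(=O)c3ccccc23)cn1` carries a piperidin-1-yl group on the carbonyl carbon, and in this assay compound 1 gives 65500 nM. Among the compounds with values here, the step of a 2.3-fold lower number from compound 1 to compound 2 (0.36 log units; beyond the scatter) is the only comparison between measured compounds that differ in one place. Compound 3 `Cc1noc(C)c1-c1nn(Cc2ccc(C(=O)NC3CC3)cc2)c(=O)c2ccccc12` differs from both of them in more than one place. In this assay compound 3 sits at > 100000 nM, which is a limit of the assay and not a number.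

Compound 4 `Cn1cc(-c2nn(Cc3ccc(C(=O)NC4CCCC4)cc3)c(=O)c3ccccc23)cn1` has not yet been measured in this assay. Compared with compound 2 it shows (cyclopentyl in place of 1-methylpiperidin-4-yl on an amide-type nitrogen). Within the data shown here, no measured step covers this exact change. Among the measured compounds shown here, the only related step, a 2.3-fold lower number from compound 1 to compound 2 (0.36 log units; beyond the scatter), places the compound without the 1-methylpiperidin-4-yl group at the higher number, and compound 4 also lacks that group. On that basis a modest rise in the number is expected, and compound 4 is estimated at 55000 nM, within a range of 20000 nM to 150000 nM, corresponding to an expected step of a 1.9-fold higher number from compound 2 to compound 4 (0.29 log units; within the scatter). Given (the limit of > 100000 nM in this assay, at which 1 of the 3 values shown sits), there is some chance that compound 4 returns only that limit.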

Compound 4, half-maximal inhibitory concentration: 16700 nM
Beside the measured number, compound 4's estimate is 3.3-fold (0.52 log units) above it; the whole stated range lies above it.
By their numbers in this assay, from the lowest: compounds 4 and 2 (each within the scatter of the next); then compound 1. At a limit, above all of these: compound 3.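

In this assay, the step of a 1.7-fold lower number from compound 2 to compound 4 (0.23 log units; within the scatter) shows that, on the amide-type nitrogen, the 1-methylpiperidin-4-yl group with its ring nitrogen can be exchanged for cyclopentyl, a ring of carbon only, without a change beyond the scatter. The step of a 3.9-fold lower number from compound 1 to compound 4 (0.59 log units; beyond the scatter) then shows that the gap to the piperidin-1-yl amide does not depend on that ring nitrogen, and among these compounds the lower numbers go with the amide hydrogen, which compound 2 and compound 4 carry and compound 1 lacks. Nothing in the data shown accounts for these numbers.

The compounds shown leave open whether a cyclohexyl ring, an open chain such as isopropyl, or a carboxylic acid on the cyclopentyl ring would keep the number in this range, and whether a methyl group on the amide nitrogen would return it to the level of compound 1. Compound 3 stands at > 100000 nM, a limit of the assay and not a number, and it differs from the others in more than one place, so the part played by its cyclopropyl amide stays unresolved.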